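Urea to Amide on a Weakly Active Scaffold

The compounds below may be only part of what the source reports. "The series", "measured", "known", "first", "only" and "open" are said of these compounds alone.

Compound 2 `COc1cc(Cl)cc(-c2nn(-c3cccc(NC(=O)Nc4ccc(Cl)c(C(F)(F)F)c4)c3)cc2-c2ccncc2)c1` gives 92% in a functional assay on SR cells (Homo sapiens) for inhibition, read by sulforhodamine B assay, with a stated time of 48 h, tested at 0.1 uM; on this read-out lower numbers stand for a stronger effect and higher numbers for a weaker effect at the one concentration tested. Among the measured compounds shown here, the only other number comes from compound 1 `O=C(Nc1cccc(-n2cc(-c3ccncc3)c(-c3cc(O)cc(Cl)c3)n2)c1)Nc1ccc(Cl)c(C(F)(F)F)c1`, which gives 98%, and the step of a number 6 percentage points lower from compound 1 to compound 2 (within the scatter) keeps the two within the scatter of each other. Compound 3 `COc1cc(Cl)cc(-c2nn(-c3cccc(NC(=O)c4cccc(C(F)(F)F)c4)c3)cc2-c2ccncc2)c1` differs from compound 2 by 3-(trifluoromethyl)phenyl in place of (4-chloro-3-(trifluoromethyl)phenyl)amino on a carbonyl carbon. For the measured compounds named here, no measured step touches this part of the molecule, and the one known step is small, so for compound 3 the change is expected to bring no change at the digits printed from compound 2 to compound 3 (within the scatter) in this assay. Compound 3 is estimated at 92%, ranging from 74% to 106%.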

Compound 3, a percentage reported as activity, at one concentration (the size of the read-out at that concentration, not a potency): 54%
The estimate for compound 3 lay 38 percentage points above the measured number; measured number below the stated range.
By their numbers in this assay, from the lowest: compound 3; then compounds 2 and 1 (each within the scatter of the next).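

Putting 3-(trifluoromethyl)phenyl in place of (4-chloro-3-(trifluoromethyl)phenyl)amino on the carbonyl carbon gives a number 38 percentage points lower from compound 2 to compound 3 (beyond the scatter) in this assay. A lower number here stands for a stronger effect, so compound 3 is clearly stronger than compound 2 at the one concentration tested. This position can therefore move the read-out well beyond the scatter, which the step on the oxygen did not do.

The change removes the chlorine and the amino nitrogen together, so the compounds shown cannot separate the two, and a nitrile or an amine in place of trifluoromethyl remains open. Nothing available gives a reason for the stronger effect.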